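A few compounds are considered here, and "the series" means these few. Any claim that something is new, unique, unknown or untested is made for them only; others in the source may bear on it.

Measured compounds:
- compound 1 `Nc1sc(-c2ccc(Cl)cc2)c(-c2ccc(Cl)cc2)c1C(=O)NC1CCCCC1`: in a functional assay on PC-3 cells (Homo sapiens) for inhibition, read by sulforhodamine B assay, with a stated time of 72 h (on this read-out higher numbers stand for weaker inhibition and lower numbers for stronger inhibition), compound 1 gives 7300 nM
- compound 2 `Nc1sc(-c2ccc(Cl)cc2)c(-c2ccc(Cl)cc2)c1C(=O)Nc1ccccc1`: compound 2 reaches only the limit of > 50000 nM in this assay
- compound 3 `Nc1sc(-c2ccc(Cl)cc2)c(-c2ccc(Cl)cc2)c1C(=O)NCc1ccccc1`: compound 3 gives 31800 nM in this assay

All three share one core and differ only in the group on the amide-type nitrogen. Compound 1, with its cyclohexyl group, stands at the lowest number of the two actual numbers, and its nearest neighbour is compound 3 a 4.4-fold higher number from compound 1 to compound 3 (0.64 log units; beyond the scatter). Replacing the cyclohexyl by phenyl gave an at least 6.8-fold higher number from compound 1 to compound 2 (0.83 log units; beyond the scatter), where the value of compound 2 is only a limit of the assay (the limit of > 50000 nM in this assay, at which 1 of the 3 values shown sits). Between the two aromatic amides the difference is an at least 1.5-fold lower number from compound 2 to compound 3 (0.19 log units; that floor lies within the scatter).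

Compound 4 `COC(=O)c1c(N)sc(-c2ccc(Cl)cc2)c1-c1ccc(Cl)cc1` carries a different change: methoxy in place of cyclohexylamino on a carbonyl carbon. For the measured compounds named here, none of the measured steps alters this carbonyl substituent in the same way; they only show that every change away from the cyclohexylamino group so far gave a higher number. On that basis a weaker inhibition is expected, with a 2.7-fold higher number from compound 1 to compound 4 (0.44 log units; beyond the scatter) as the estimated step, though the direction rests on analogy rather than on a matching step. For compound 4 the expected value in this assay is 20000 nM, within a range from 5000 nM to 60000 nM.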

Compound 4, half-maximal inhibitory concentration: 2780 nM
For compound 4 the middle estimate is 7.2-fold (0.86 log units) above the measured one, outside the stated range (below it).
By their numbers in this assay, from the lowest: compound 4; then compound 1; then compound 3. At a limit, above all of these: compound 2.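

In this assay, the carbonyl carbon of this core does not need an amide-type nitrogen group for activity: swapping cyclohexylamino, with its carbon ring and hydrogen-bond donor, for the much smaller methoxy reverses the direction of every earlier change, giving a 2.6-fold lower number from compound 1 to compound 4 (0.42 log units; beyond the scatter). The gap to the two aromatic amides is wider, with an 11-fold lower number from compound 3 to compound 4 (1.06 log units; beyond the scatter) and an at least 17-fold lower number from compound 2 to compound 4 (1.25 log units; beyond the scatter), so all three amide-type groups shown give higher numbers than methoxy at this carbonyl carbon. The last of these steps is only a floor, as the value of compound 2 is a limit and not a number: the limit of > 50000 nM in this assay, at which 1 of the 4 values shown sits.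

Compound 4 loses the ring, the nitrogen and the hydrogen-bond donor in a single change, and the compounds shown do not tell which of these losses matters, or why the number falls. Ethoxy or the free carboxylic acid on the same carbonyl carbon would test whether the gain extends beyond methoxy, while methylamino would show how an amide-type nitrogen behaves without a ring.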